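Pyrazole amides: a chloro-to-methoxy swap on the pyridine amide

This account rests on a few compounds, and the source may have more. Where it says the series, first, only, none or still open, it means among the compounds named here.

Three compounds were measured in a functional assay on A-375 cells (Homo sapiens) for antiproliferative activity, read by MTT assay, with a stated time of 48 h; on this read-out higher numbers stand for weaker inhibition and lower numbers for stronger inhibition:

Compound 1 `Cc1ccc(-c2cc(NC(=O)c3ccc(Cl)nc3)n[nH]2)cc1` gave 6880 nM.
Compound 2 `COc1ccc(C(=O)Nc2cc(-c3ccc(C)cc3)[nH]n2)cn1` gave 8420 nM.
Compound 3 `O=C(Nc1cc(-c2ccc(Br)cc2)[nH]n1)c1cccnc1Cl` gave 8220 nM.

Compound 1 and compound 2 share a core and differ in one place: methoxy in place of chloro on an aromatic carbon. That change made a step of a 1.2-fold higher number from compound 1 to compound 2 (0.09 log units; within the scatter) in this assay. Compound 3 and compound 1 have different cores; the difference between the two cores is not broken down here. Compound 3 stands within the scatter of both compound 1 and compound 2, so no order among the three can be read from these numbers.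

Compound 4 `COc1ncccc1C(=O)Nc1cc(-c2ccc(Br)cc2)[nH]n1` has not yet been measured. It differs from compound 3 in one place: methoxy in place of chloro on an aromatic carbon. For the measured compounds named here, this is the same kind of change as the one from compound 1 to compound 2, but not the same: in compound 1 to compound 2 the place is para to a large group, whereas in compound 3 to compound 4 it is ortho to a large group.

Going by the values given here, because the only measured example of this change gave a 1.2-fold higher number from compound 1 to compound 2 (0.09 log units; within the scatter), compound 4 is expected to sit close to compound 3, with a step of about a 1.2-fold higher number from compound 3 to compound 4 (0.06 log units; within the scatter) in this assay; the single precedent and the differing place keep the range wide. Compound 4 is therefore estimated at 9500 nM, between 4500 nM and 22000 nM.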

Compound 4, half-maximal inhibitory concentration: 11100 nM
The estimate for compound 4 lay 1.2-fold (0.07 log units) below the measured number; low and high end bracket the measured number.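

In this assay, the same swap of methoxy in place of chloro, here on an aromatic carbon next to the ring nitrogen and ortho to a large group, made a step of a 1.4-fold higher number from compound 3 to compound 4 (0.13 log units; within the scatter). Set beside the earlier step, the change carries over from one core to the other with no difference that these numbers can resolve: the same change on two cores in this assay, a 1.2-fold higher number (0.09 log units; within the scatter) from compound 1 to compound 2 and a 1.4-fold higher number (0.13 log units; within the scatter) from compound 3 to compound 4, 1.1-fold (0.04 log units) apart, within the scatter of two such steps. For the compounds shown here, this shows that on these two cores the swap stays within the scatter, but it does not show that the change is without effect in general, since it rests on only two pairs, neither step is large enough to be read as a real shift, and the two pairs differ both in the core and in the place of the swap, so the two influences cannot be separated.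

The compounds shown leave open whether another group at this place, such as an amine, a carboxylic acid or a longer alkoxy chain, would move the number beyond the scatter. They also leave open whether the swap would behave alike with a group such as nitrile or trifluoromethyl in place of the methyl of compound 1 or the bromo of compound 3.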